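Methylating the phenol: the same change tested on a second core

This account rests on a few compounds, and the source may have more. Where it says the series, first, only, none or still open, it means among the compounds named here.

Measured so far:
- compound 1 `O=C(/C=C\Nc1ccc(O)cc1)c1cn(-c2ccccc2)nc1-c1ccccc1`: 4290 nM
- compound 2 `COc1ccc(N/C=C\C(=O)c2cn(-c3ccccc3)nc2-c2ccccc2)cc1`: > 50000 nM
- compound 3 `COc1cc(-c2nn(-c3ccccc3)cc2C(=O)/C=C\Nc2ccc(O)cc2)cc(OC)c1OC`: 1800 nM

In a functional assay on U-87MG ATCC cells (Homo sapiens) for antiproliferative activity, read by MTT assay, with a stated time of 48 h (on this read-out higher numbers stand for weaker inhibition and lower numbers for stronger inhibition), compound 1 gives 4290 nM. Compound 2, which carries methyl in place of hydrogen on an oxygen on an aromatic ring, reaches only the assay limit (the limit of > 50000 nM in this assay, at which 1 of the 3 values shown sits), so its value is a limit and not a number. The step is an at least 11-fold higher number from compound 1 to compound 2 (1.06 log units; beyond the scatter). Compound 3 shares the hydroxyphenyl end with compound 1 but sits on another core; how the two cores differ is not broken down here. Compound 4 `COc1ccc(N/C=C\C(=O)c2cn(-c3ccccc3)nc2-c2cc(OC)c(OC)c(OC)c2)cc1` is not yet measured and carries methyl in place of hydrogen on an oxygen on an aromatic ring, the same change as in compound 2. Because the step of an at least 11-fold higher number from compound 1 to compound 2 (1.06 log units; beyond the scatter) was so large, the step from compound 3 to compound 4 is expected to be similarly large, about a 17-fold higher number from compound 3 to compound 4 (1.22 log units; beyond the scatter), although this rests on a single pair. Compound 4 is therefore expected to give about 30000 nM, between 8000 nM and 50000 nM, quite possibly only as a limit.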

Compound 4, half-maximal inhibitory concentration: 12800 nM
The estimate for compound 4 lay 2.3-fold (0.37 log units) above the measured number; measured number inside the range.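

In this assay, putting methyl in place of hydrogen on the oxygen, which turns hydroxy into methoxy, weakens inhibition on both cores: the same change on two cores in this assay, an at least 11-fold higher number (1.06 log units; beyond the scatter) from compound 1 to compound 2 and a 7.1-fold higher number (0.85 log units; beyond the scatter) from compound 3 to compound 4; the limit leaves it open whether they differ

For the compounds shown here, the direction of the change therefore carries over from the core of compound 1 to the core of compound 3, and a 7.1-fold higher number from compound 3 to compound 4 (0.85 log units; beyond the scatter) is the only one of these two steps measured between two actual numbers. Compound 2 gives a limit and not a number, so these two pairs do not show whether the size of the change carries over.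

Among the methoxy compounds, 3,4,5-trimethoxyphenyl in place of phenyl gives an at least 3.9-fold lower number from compound 2 to compound 4 (0.59 log units; beyond the scatter), but what that swap does in other settings stays open. Also open, from the compounds shown here alone, is what an amine or an ethoxy group would do in place of the hydroxy.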